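Swapping 2,6-difluorophenyl for isobutyl on an amide carbonyl

The source may hold more compounds than are shown below. What is called first, only, known or untested is meant among the compounds shown, and "the series" means these compounds.

In a functional assay on HepG2 cells (Homo sapiens) for inhibition, read by sulforhodamine B assay, with a stated time of 3 days (a lower number here means a stronger inhibitor, a higher number a weaker inhibitor), compound 1 (`O=C1Nc2ccc(F)cc2/C1=C\C(=O)c1ccc[nH]1`) gives a reading of 3120 nM and compound 2 (`O=C1Nc2ccc(F)cc2/C1=C\C(=O)c1cccs1`) gives a reading of 8780 nM on the same scale. Compound 3 (`CN1CCN(c2cccc(N/C=C3\C(=O)Nc4ccc(NC(=O)c5c(F)cccc5F)cc43)c2)CC1`) reads 3030 nM and so cannot be told apart from compound 1, while both lie clearly under compound 2.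

Compound 4 (`CC(C)CC(=O)Nc1ccc2c(c1)/C(=C/Nc1cccc(N3CCN(C)CC3)c1)C(=O)N2`) keeps all of compound 3 except one group: isobutyl in place of 2,6-difluorophenyl on a carbonyl carbon whose other neighbour is an amide-type nitrogen (isobutyl in place of 2,6-difluorophenyl on a carbonyl carbon). Among the compounds with values here, the only measured step that bears on this also exchanges a group on a carbonyl carbon, with thiophen-2-yl in place of 1H-pyrrol-2-yl (a 2.8-fold higher number from compound 1 to compound 2 (0.45 log units; beyond the scatter)). That step is modest, but it was measured on a different core and swaps one ring for another. Within the data shown here, no measured step replaces a ring with an open chain, so it guides the likely size only weakly and says nothing firm about direction.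

A small change is therefore expected, probably not beyond the scatter, with a tentative lean towards a higher number. In numbers, the expected change is a 1.5-fold higher number from compound 3 to compound 4 (0.17 log units; within the scatter) (a rough expectation from very few compounds). In this assay the estimated value for compound 4 is 4500 nM (expected range 1500 nM to 14000 nM).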

Compound 4, half-maximal inhibitory concentration: 5070 nM
Compound 4: the middle estimate sits 1.1-fold (0.05 log units) below what was measured; low and high end bracket the measured number.
By their numbers in this assay, from the lowest: compounds 3, 1, 4 and 2 (each within the scatter of the next, the first and the last beyond it).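

In this assay, isobutyl in place of 2,6-difluorophenyl on a carbonyl carbon whose other neighbour is an amide-type nitrogen gives a 1.7-fold higher number from compound 3 to compound 4 (0.22 log units; within the scatter) and so stays within the usual scatter. Within the data shown here, this is the first measured pair in which an open chain takes the place of a ring: the six-membered aromatic ring and both fluorines leave, the group shrinks from 8 heavy atoms to 4, and no readable change in the number follows, so for compounds 3 and 4 the ring is not needed to keep a reading of this size. No measurement shown here accounts for this tolerance of the exchange.

From the compounds shown here alone, with only 2,6-difluorophenyl and isobutyl compared at this place, it remains open whether an amine, a carboxylic acid or a longer chain on the same carbonyl carbon would move the number beyond the scatter in either direction. Going by these compounds, it is also open whether the same exchange would read alike if the rest of the molecule were different, as compounds 3 and 4 share everything else.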